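The source may hold more compounds than are shown below. What is called first, only, known or untested is meant among the compounds shown, and "the series" means these compounds.

Compound 1 `Oc1ccc(-c2cc(-c3cccnc3)nc(-c3cccc(Cl)c3)c2)cc1`: 55.2% in an assay on isolated protein for inhibition of DNA topoisomerase 1 (Homo sapiens), with a stated time of 30 min, tested at 100 uM; on this read-out higher numbers stand for a stronger effect at the one concentration tested and lower numbers for a weaker effect
Compound 3 `Oc1ccc(-c2cc(-c3ccncc3)nc(-c3cccc(Cl)c3)c2)cc1`: 29.2% in this assay
Compound 2 `Oc1ccc(-c2cc(-c3ccsc3)nc(-c3ccccc3Cl)c2)cc1`: 4.1% in this assay

Compound 3 stands second of these three numbers, with compound 1 above it and compound 2 below it, both gaps beyond the scatter. Compound 4 `Oc1ccc(-c2cc(-c3ccsc3)nc(-c3cccc(Cl)c3)c2)cc1` arises from compound 3 by one change: thiophen-3-yl in place of pyridin-4-yl on an aromatic carbon. For the measured compounds named here, no measured step makes exactly this swap. Going by the values given here, the only single-place step, a number 26 percentage points lower from compound 1 to compound 3 (beyond the scatter), exchanges pyridin-3-yl for pyridin-4-yl and shows that a change at this spot can move the number by a modest amount. Compound 2 carries thiophen-3-yl but differs from compound 3 in a second place as well, so its low value gives only a hint. A downward step is therefore expected, a number 14.2 percentage points lower from compound 3 to compound 4 (beyond the scatter), and compound 4 is estimated at 15%, within a range from 0% to 40%.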

Compound 4, a percentage reported as inhibition, at one concentration (the size of the read-out at that concentration, not a potency): 26%
For compound 4 the middle estimate is 11 percentage points below the measured one; low and high end bracket the measured number.
By their numbers in this assay, from the lowest: compound 2; then compounds 4 and 3 (each within the scatter of the next); then compound 1.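

Swapping pyridin-4-yl for thiophen-3-yl at this position leaves the number within the scatter (a number 3.2 percentage points lower from compound 3 to compound 4 (within the scatter)), so here the five-membered sulfur ring and the six-membered nitrogen ring cannot be told apart. Against pyridin-3-yl, the same thiophen-3-yl gives a clear drop (a number 29.2 percentage points lower from compound 1 to compound 4 (beyond the scatter)), so among these three groups pyridin-3-yl alone stands out. With thiophen-3-yl held fixed, 3-chlorophenyl in place of 2-chlorophenyl gives a clear rise (a number 21.9 percentage points higher from compound 2 to compound 4 (beyond the scatter)), so the low number of compound 2 goes with its 2-chlorophenyl group, not with thiophen-3-yl.

No evidence here explains these differences. From the compounds shown here alone, how an amine or a carboxylic acid would behave at this position remains open.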